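Moving from 3-Fluorophenyl to 4-Fluorophenyl on the Sulfonyl Sulfur

The compounds below may be only part of what the source reports. "The series", "measured", "known", "first", "only" and "open" are said of these compounds alone.

Values in an ADME assay on MT4 cells (Homo sapiens) for cytotoxicity, with a stated time of 5 days; on this read-out higher numbers stand for lower toxicity in this test and lower numbers for higher toxicity in this test:
- compound 1 `O=c1[nH]c2ccc(Cl)cc2n1S(=O)(=O)c1c(Cl)cccc1Cl`: > 331000 nM (a limit of the assay)
- compound 2 `O=c1[nH]c2ccc(Cl)cc2n1S(=O)(=O)c1ccccc1F`: > 382000 nM (a limit of the assay)
- compound 3 `O=c1[nH]c2ccc(Cl)cc2n1S(=O)(=O)c1cccc(F)c1`: 128000 nM

For the measured compounds named here, compound 3 stands alone, as its 128000 nM is the only actual number in this assay. Compound 1 reports only a limit, > 331000 nM. Compound 2 likewise reports only a limit, > 382000 nM.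

The next compound, compound 4 `O=c1[nH]c2ccc(Cl)cc2n1S(=O)(=O)c1ccc(F)cc1`, differs from compound 3 by a single change: 4-fluorophenyl in place of 3-fluorophenyl on a sulfonyl sulfur. It carries 4-fluorophenyl in place of 3-fluorophenyl on a sulfonyl sulfur.

Going by the values given here, one measured step bears on this change, an at least 2.9-fold lower number from compound 2 to compound 3 (0.47 log units; beyond the scatter). That step exchanges 2-fluorophenyl for 3-fluorophenyl at the same sulfonyl sulfur, and it shows that such an exchange can move the read-out beyond the scatter. Among the compounds with values here, its full size is unknown, since it starts from a limit, and no measured compound yet carries 4-fluorophenyl.

A modest move to a higher number is therefore expected, possibly no larger than the scatter. The expected step is a 1.4-fold higher number from compound 3 to compound 4 (0.15 log units; within the scatter). For compound 4 the estimate is 180000 nM, with an expected range from 70000 nM to 382000 nM.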

Compound 4, half-maximal cytotoxic concentration: >= 355000 nM
Compound 4: no number, only a limit (the forecaster's own chance of this, stated with the estimate: 35%); middle value at least 1.9-fold (0.29 log units) away from the limit.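

In this assay, 4-fluorophenyl in place of 3-fluorophenyl on the sulfonyl sulfur gives an at least 2.7-fold higher number from compound 3 to compound 4 (0.44 log units; beyond the scatter), so the read-out at this position responds to where the fluorine sits on the ring, even though the two groups hold the same atoms. Taken with an at least 2.9-fold lower number from compound 2 to compound 3 (0.47 log units; beyond the scatter), this shows that 3-fluorophenyl gives the lower number against both other fluorophenyl groups, each step lying beyond the scatter, which makes compound 3 the most toxic of these three in this test rather than the start of a trend running through the series. The value of compound 4 is only a limit, so the full size of its step remains unknown: the limit of >= 355000 nM in this assay, at which 1 of the 4 values shown sits.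

The step between compound 2 and compound 4 cannot be read, as both values are limits, which leaves the order of 2-fluorophenyl and 4-fluorophenyl unsettled. From the compounds shown here alone, it also remains open whether the lower number belongs to fluorine alone or would recur with 3-chlorophenyl, 3-methoxyphenyl or a phenyl ring carrying an amine or a carboxylic acid at that place.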